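Swapping one aryl amide for another on a shared core

A few compounds are considered here, and "the series" means these few. Any claim that something is new, unique, unknown or untested is made for them only; others in the source may bear on it.

Two compounds share a core and differ only in the group on an amide-type nitrogen. Compound 1 `CNC(=O)c1c(O)c2cccnc2n(-c2ccccc2)c1=O` carries a methyl there; compound 2 `Cc1ccc(NC(=O)c2c(O)c3cccnc3n(-c3ccccc3)c2=O)cc1` carries a 4-methylphenyl. In a functional assay on the whole organism for inhibition, with Rattus norvegicus as the target, read by paw edema, at a dose of 100 mg/kg by the oral route (on this read-out higher numbers stand for more inhibition at the one dose given (going by the name of the read-out) and lower numbers for less inhibition), compound 1 gives 9.6%, and compound 2 gives -3.5%. That single change made a number 13.1 percentage points lower from compound 1 to compound 2 (beyond the scatter), so compound 2 stands lowest of the two numbers measured, with compound 1 above it.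

Compound 3 `O=C(Nc1cccc(Cl)c1)c1c(O)c2cccnc2n(-c2ccccc2)c1=O` keeps the same core and makes one further change on that amide-type nitrogen: 3-chlorophenyl in place of 4-methylphenyl on an amide-type nitrogen. For the measured compounds named here, the only measured step, from methyl to 4-methylphenyl, is a different kind of change from exchanging one substituted phenyl for another, so it bears on compound 3 only loosely: it shows that the group on this nitrogen can move the read-out by a modest amount. Nothing measured separates two aryl groups from each other, so the expected step is a number 6.5 percentage points higher from compound 2 to compound 3 (within the scatter), within the scatter. Compound 3 is therefore estimated at 3%, between -15% and 25%.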

Compound 3, a percentage reported as inhibition, in the whole organism at one dose (the size of the read-out at that dose, not a potency): 7.6%
For compound 3 the middle estimate is 4.6 percentage points below the measured one, and the stated range covers the measured number.
By their numbers in this assay, from the lowest: compound 2; then compounds 3 and 1 (each within the scatter of the next).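

In this assay, the exchange on the amide-type nitrogen gives a number 11.1 percentage points higher from compound 2 to compound 3 (beyond the scatter), the first sign in this set that two substituted phenyl groups at this place can read differently. Set against the methyl group, 3-chlorophenyl gives a number 2 percentage points lower from compound 1 to compound 3 (within the scatter), so a phenyl ring on this nitrogen does not by itself lower the read-out, and among the compounds shown the low number belongs to compound 2 alone. Nothing available here explains the difference between the two phenyl groups.

Because 3-chlorophenyl differs from 4-methylphenyl in both the kind of substituent and its place on the ring, these compounds cannot show whether the chlorine, its place or the loss of the methyl group accounts for the step. An unsubstituted phenyl group would help to separate these possibilities, while a longer chain or a phenyl ring bearing a carboxylic acid or an amine would test whether any group on this nitrogen can lift the read-out well clear of these small numbers.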